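Swapping the Amide-Bearing Tail for a Triazole on Compound 3

The source may hold more compounds than are shown below. What is called first, only, known or untested is meant among the compounds shown, and "the series" means these compounds.

The series shares one core, seen in compound 1 `O=C(NCCCNc1nc(Nc2cccc(F)c2)ncc1C1CC1)C1CCC1`, and varies the aryl group on the amine nitrogen. In an assay on RAW264.7 cells for inhibition of serine/threonine-protein kinase TBK1 (Mus musculus), read by ELISA, with stated times of 30 min and 6 h (a lower number here means a stronger inhibitor, a higher number a weaker inhibitor), compound 1 gives 1300 nM. Compound 2 `CC(C)n1cc(Nc2ncc(C3CC3)c(NCCCNC(=O)C3CCC3)n2)cn1` gives 81 nM, and the step of a 16-fold lower number from compound 1 to compound 2 (1.21 log units; beyond the scatter) shows how strongly this position can move the result. Compound 3 `CN1CCN(C(=O)c2ccc(Nc3ncc(C4CC4)c(NCCCNC(=O)C4CCC4)n3)cc2)CC1` is reported in this assay as "not active" (no number reported), so no number places it against the other two; it stands as the weakest entry of the three only in the sense that no inhibition was recorded.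

Compound 4 `O=C(NCCCNc1nc(Nc2ccc(-n3cncn3)cc2)ncc1C1CC1)C1CCC1` differs from compound 3 in one place: 1H-1,2,4-triazol-1-yl in place of (4-methylpiperazin-1-yl)carbonyl on an aromatic carbon. For the measured compounds named here, no measured step among the three compounds covers this exchange. Going by the values given here, the only step on record concerns a different position and was large, which shows that changes at the aryl group can shift the result well beyond the scatter, but it gives no direction for this particular change. Since compound 3 itself has no number, the expectation for compound 4 must rest on the weak result of compound 1 and the stronger one of compound 2 as bounds. Compound 4 is estimated in this assay at 1500 nM, with a range from 250 nM to 10000 nM, and a real chance that no number is obtained.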

Compound 4, half-maximal inhibitory concentration: 150 nM
Compound 4: middle estimate off by 10-fold (1.00 log units), on the high side; measured number below the stated range.
By their numbers in this assay, from the lowest: compounds 2 and 4 (each within the scatter of the next); then compound 1.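

Compound 3 is reported without a number in this assay and so the exchange leading to compound 4 cannot be read as a step, while compound 4 gives 150 nM there. Nothing on hand bears on this result. The compounds shown leave open how much the 1H-1,2,4-triazol-1-yl group itself contributes to that value.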